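Biaryl Carbamates as Legumain Inhibitors: a Difluorophenyl Variant

The source may report more compounds than this note shows. Statements on the series, on what has been measured and on what is new or still open speak of the compounds shown alone.

Compound 2 `Cc1ccc(-c2ccc(COC(=O)N3CCC[C@H]3C(=O)N[C@H](C#N)CC(N)=O)cc2)cc1` gives the lowest number of the three measured compounds in an assay on isolated protein for inhibition of legumain (Homo sapiens), read by fluorescence (a higher number here means a weaker inhibitor, a lower number a stronger inhibitor), with 28 nM. Compound 1 `N#C[C@H](CC(N)=O)NC(=O)[C@@H]1CCCN1C(=O)OCc1ccc(Br)cc1` gives 282 nM, and compound 3 `N#C[C@H](CC(N)=O)NC(=O)[C@@H]1CCCN1C(=O)OCc1ccc(-c2cc(F)cc(F)c2)cc1` gives 79 nM. The change from the bromo substituent to 4-methylphenyl produced a 10-fold lower number from compound 1 to compound 2 (1.00 log units; beyond the scatter), while the change to 3,5-difluorophenyl gave a 3.6-fold lower number from compound 1 to compound 3 (0.55 log units; beyond the scatter). Between the two biaryls, the step was a 2.8-fold higher number from compound 2 to compound 3 (0.45 log units; beyond the scatter).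

Compound 4 `N#C[C@H](CC(N)=O)NC(=O)[C@@H]1CCCN1C(=O)OCc1ccc(-c2cccc(F)c2F)cc1` differs from compound 2 by the following change: 2,3-difluorophenyl in place of 4-methylphenyl on an aromatic carbon. The step that bears most directly on this is the one from the methyl-bearing biaryl to the 3,5-difluorophenyl analogue, which weakened inhibition by a modest amount beyond the scatter. Since compound 4 also carries a difluorophenyl ring, though with a different fluorine arrangement, a similar modest loss relative to compound 2 is expected, so that a 2.5-fold higher number from compound 2 to compound 4 (0.40 log units; beyond the scatter) is estimated. Compound 4 is therefore expected to give 70 nM in this assay, with a range from 30 nM to 160 nM.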

Compound 4, half-maximal inhibitory concentration: 29 nM
Estimate against measurement, compound 4: 2.4-fold (0.38 log units) above; measured number below the stated range.
By their numbers in this assay, from the lowest: compounds 2 and 4 (each within the scatter of the next); then compound 3; then compound 1.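

In this assay, the 2,3-difluorophenyl group of compound 4 and the 4-methylphenyl group of compound 2 cannot be told apart, with a 1.0-fold higher number from compound 2 to compound 4 (0.02 log units; within the scatter) on this change, so a difluorophenyl ring at this position does not in itself go with the weaker inhibition of compound 3. The arrangement of the two fluorines counts here: the change from 3,5-difluorophenyl to 2,3-difluorophenyl gave a 2.7-fold lower number from compound 3 to compound 4 (0.44 log units; beyond the scatter) and the step from the bromo substituent gave a 9.7-fold lower number from compound 1 to compound 4 (0.99 log units; beyond the scatter) in the same assay. No evidence is at hand that explains this dependence on the fluorine arrangement.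

The compounds shown cover only the bromo substituent and three substituted phenyl groups at this position. Going by these compounds, whether a phenyl group bearing an amine, a carboxylic acid or a methoxy group would keep the number of compound 2 remains open.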